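Swapping a Propylphenyl for an Ethylphenyl: Expected Solubility

This account rests on a few compounds, and the source may have more. Where it says the series, first, only, none or still open, it means among the compounds named here.

Compound 1 `CCc1ccc(-c2nc3c(c(C)nn3-c3ccccc3)c(-c3ccccc3C(=O)O)c2C#N)cc1` and compound 2 `CCCc1ccc(-c2nc3c(c(C)nn3-c3ccccc3)c(-c3ccccc3O)c2C#N)cc1` share the same fused core and were both tested in a physicochemical assay for solubility, read by spectrophotometry, in phosphate buffer, with a stated time of 18 h, at pH 7.4; a higher number here means a more soluble compound, a lower number a less soluble compound. In this assay compound 1 gives 33000 nM, and in the same measurement compound 2 gives 6500 nM. Among these two numbers compound 2 stands lowest, and the gap to compound 1 lies beyond the usual scatter.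

Compound 3 `CCc1cccc(-c2nc3c(c(C)nn3-c3ccccc3)c(-c3ccccc3O)c2C#N)c1` has not yet been measured. It differs from compound 2 in one place: 3-ethylphenyl in place of 4-propylphenyl on an aromatic carbon. Going by the values given here, no measured pair follows this exact change, so the expectation rests on compound 2 alone. Since a closely related group replaces another of much the same kind, the step of a 1.2-fold higher number from compound 2 to compound 3 (0.09 log units; within the scatter) is expected to be small, in either direction, and not beyond the scatter. Compound 3 is therefore estimated to give about 8000 nM, with a range from 3000 nM to 20000 nM.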

Compound 3, solubility: 11000 nM
Estimate against measurement, compound 3: 1.4-fold (0.14 log units) below; measured number inside the range.
By their numbers in this assay, from the lowest: compounds 2 and 3 (each within the scatter of the next); then compound 1.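

In this assay, placing 3-ethylphenyl where 4-propylphenyl stood, on the aromatic carbon next to the ring nitrogen, gives a 1.7-fold higher number from compound 2 to compound 3 (0.23 log units; within the scatter). Going by these compounds alone, this is the first measured pair that differs in one place, and it shows that this particular swap leaves the read-out within the usual scatter. Nothing measured here offers an explanation for that result.

The swap alters the length of the chain and where it sits on the phenyl ring together, so these compounds cannot show what each change does alone, or whether the two changes offset each other. Also open, as far as these compounds go, is whether a much longer chain, an amine or a carboxylic acid on that phenyl ring would produce a step beyond the scatter.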